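The source may hold more compounds than are shown below. What is called first, only, known or untested is meant among the compounds shown, and "the series" means these compounds.

Measured compounds:
compound 1, `Cc1cc(O)cc(-c2nn(CC#N)cc2-c2ccnc(-c3ccc(Oc4ccccc4)cc3)c2)c1`: 8920 nM
compound 2, `COc1cc(C)cc(-c2nn(CC#N)cc2-c2ccnc(-c3ccc(N(C)C)cc3)c2)c1`: > 100000 nM

Both were examined in a functional assay on RXF 393 cells (Homo sapiens) for inhibition, read by sulforhodamine B assay, with a stated time of 48 h; on this read-out lower numbers stand for higher toxicity in this test and higher numbers for lower toxicity in this test. Compound 1 gives 8920 nM in this assay. Compound 2 gives only > 100000 nM, which is a limit of the test and not a measured number. On these data alone, compound 2 thus stands at the limit of > 100000 nM in this assay, at which 1 of the 2 values shown sits, so its true value is unknown beyond that boundary.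

Compound 3, `Cc1cc(O)cc(-c2nn(CC#N)cc2-c2ccnc(-c3ccc(N(C)C)cc3)c2)c1`, differs from compound 2 in one place: hydrogen in place of methyl on an oxygen on an aromatic ring. For the measured compounds named here, compound 1 also carries the hydroxy group but differs from compound 2 elsewhere too, so their two values show only that one is a number and the other a limit; no single step can be read from them.

For the change from compound 2 to compound 3 a step of an at least 2.0-fold lower number from compound 2 to compound 3 (0.30 log units; that floor lies within the scatter) is expected, toward higher toxicity but modest and uncertain. Compound 3 is expected to give around 50000 nM, within 12000 nM to 200000 nM.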

Compound 3, concentration lethal to 50% of the cells: > 100000 nM
Compound 3: a limit, no number; the forecaster's own chance of this, stated with the estimate: 45%; middle value at least 2.0-fold (0.30 log units) from the limit.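

In this assay compound 3 gives only a limit of the test, > 100000 nM, and not a number. Hydroxy in place of methoxy therefore does not bring compound 3 down to a measured value, but the step between the two limits cannot be read. With the hydroxy group kept, dimethylamino in place of phenoxy gives an at least 11-fold higher number from compound 1 to compound 3 (1.04 log units; beyond the scatter), so the hydroxy group alone does not go with a measured toxicity, and of these two compounds only compound 1 reaches a number.

On these data alone, whether methoxy to hydroxy makes any difference at all stays open while both compounds sit at the same boundary: the limit of > 100000 nM in this assay, at which 2 of the 3 values shown sit. Also open is how the shared core would respond to other groups in place of phenoxy, such as a benzyloxy group, a primary amine or a carboxylic acid.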